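Shifting the methyl on the phenoxy group of compound 3

This account rests on a few compounds, and the source may have more. Where it says the series, first, only, none or still open, it means among the compounds named here.

Measured so far in an ADME assay on MT2 cells (Homo sapiens) for cytotoxicity; a higher number here means that more compound is tolerated, a lower number that less compound is tolerated:
compound 1 `COc1ccnc(Nc2ccc(Cl)c(OCC=C(C)C)c2)n1` gives 9000 nM;
compound 2 `C/C=C/COc1cc(Nc2nccc(OC)n2)ccc1Cl` gives 17000 nM;
compound 3 `COc1ccnc(Nc2ccc(Cl)c(Oc3ccccc3C)c2)n1` gives 13000 nM.

Among these three numbers, that of compound 3 sits in the middle, separated from the others by a 1.4-fold higher number from compound 1 to compound 3 (0.16 log units; within the scatter) and a 1.3-fold lower number from compound 2 to compound 3 (0.12 log units; within the scatter), both within the scatter, so the three compounds cannot be told apart here. Compound 4 `COc1ccnc(Nc2ccc(Cl)c(Oc3cccc(C)c3)c2)n1` differs from compound 3 by 3-methylphenyl in place of 2-methylphenyl on an oxygen on an aromatic ring. For the measured compounds named here, no measured step swaps one methylphenyl for another. The steps that brought 2-methylphenyl in were small, and a 1.9-fold higher number from compound 1 to compound 2 (0.28 log units; within the scatter) was small as well, so nothing measured points to a change beyond the scatter in this assay. Compound 4 is therefore estimated at 13000 nM, with a range from 6000 nM to 28000 nM. The expected step is no change at the digits printed from compound 3 to compound 4 (within the scatter).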

Compound 4, half-maximal cytotoxic concentration: 18000 nM
Compound 4: middle estimate off by 1.4-fold (0.14 log units), on the low side, and the stated range covers the measured number.
By their numbers in this assay, from the lowest: compounds 1, 3, 2 and 4 (each within the scatter of the next).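

In this assay, for the compounds shown here, the swap of 2-methylphenyl for 3-methylphenyl on this oxygen gives a 1.4-fold higher number from compound 3 to compound 4 (0.14 log units; within the scatter) and is the first measured exchange of one methylphenyl for another, so compounds 3 and 4 cannot be told apart here. Against the two chains, a 1.1-fold higher number from compound 2 to compound 4 (0.02 log units; within the scatter) and a 2.0-fold higher number from compound 1 to compound 4 (0.30 log units; within the scatter) show that compound 4 cannot be told apart from those compounds either. As far as these compounds go, whether a carboxylic acid or an amine in place of the methyl would move the number beyond the scatter stays open. No measured evidence bears on these small steps.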